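A few compounds are considered here, and "the series" means these few. Any claim that something is new, unique, unknown or untested is made for them only; others in the source may bear on it.

Compound 3 `COc1ccc(-c2cn3ccnc3c(-c3ccc4ncn(C5CCCCC5)c4c3)n2)cc1` carries a 4-methoxyphenyl group and stands highest of the three compounds measured in a functional assay on KM12 cells (Homo sapiens) for inhibition, read by sulforhodamine B assay, with a stated time of 48 h, tested at 10 uM (a higher number here means more inhibition at the concentration tested (going by the name of the read-out), a lower number less inhibition), where compound 3 gives 83.2%. Compound 1 `Brc1cn2ccnc2c(-c2ccc3ncn(C4CCCCC4)c3c2)n1` gives 67.7% and compound 2 `c1ccc(-c2cn3ccnc3c(-c3ccc4ncn(C5CCCCC5)c4c3)n2)cc1` gives 49%. Compound 4 `O=Cc1ccc(-c2cn3ccnc3c(-c3ccc4ncn(C5CCCCC5)c4c3)n2)cc1` differs from compound 3 in one place: formyl in place of methoxy on an aromatic carbon. Among the compounds with values here, no measured step swaps one group on this ring for another, so the nearest guide is a number 34.2 percentage points higher from compound 2 to compound 3 (beyond the scatter), which shows that a group on this ring can matter a great deal, read alongside a number 15.5 percentage points higher from compound 1 to compound 3 (beyond the scatter) and a number 18.7 percentage points lower from compound 1 to compound 2 (beyond the scatter). Because a number 34.2 percentage points higher from compound 2 to compound 3 (beyond the scatter) was large, exchanging the group is expected to shift the number, most likely downward. Compound 4 is therefore estimated at 65%, between 40% and 88%, an expected step of a number 18.2 percentage points lower from compound 3 to compound 4 (beyond the scatter).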

Compound 4, a percentage reported as inhibition, at one concentration (the size of the read-out at that concentration, not a potency): 3.69%
Estimate against measurement, compound 4: 61.3 percentage points above; the whole stated range lies above it.
By their numbers in this assay, from the lowest: compound 4; then compound 2; then compound 1; then compound 3.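

Formyl and methoxy each have 2 heavy atoms and sit at the same place on the six-membered aromatic ring, yet exchanging one for the other nearly abolishes the inhibition in this assay (a number 79.5 percentage points lower from compound 3 to compound 4 (beyond the scatter)). The formyl compound also falls well short of the compound with only hydrogen there (a number 45.3 percentage points lower from compound 2 to compound 4 (beyond the scatter)) and of the bromo compound (a number 64 percentage points lower from compound 1 to compound 4 (beyond the scatter)), so a group at this place can lower the number as well as raise it. Nothing available here explains the drop. From the compounds shown here alone, how an amine or a carboxylic acid at this same place would move the number remains open.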